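The compounds below may be only part of what the source reports. "The series", "measured", "known", "first", "only" and "open" are said of these compounds alone.

Measured values in the series:

Compound 1, `O=c1[nH]c(SCc2cc([N+](=O)[O-])cc([N+](=O)[O-])c2)nc2ccccc12`, in an ADME assay on MRC5 cells (Homo sapiens) for cytotoxicity, read by neutral red uptake (on this read-out higher numbers stand for lower toxicity in this test and lower numbers for higher toxicity in this test), gives > 64000 nM, which is a limit of the assay and not a number.
Compound 2, `O=c1[nH]c(SCc2ccccc2)nc2ccccc12`, in this assay gives > 64000 nM, again a limit of the assay.
Compound 3, `O=c1[nH]c(SCc2ccccc2Cl)nc2ccccc12`, in this assay gives > 65000 nM, also a limit of the assay.

Among the measured compounds shown here, the one measured pair differing in a single place is compound 2 to compound 3. The change is chloro in place of hydrogen on an aromatic carbon. The step is a step that the two limits leave unreadable from compound 2 to compound 3; both values sit at limits, the limit of > 64000 nM in this assay, at which 2 of the 3 values shown sit, and (the limit of > 65000 nM in this assay, at which 1 of the 3 values shown sits), so no size can be read from them.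

Compound 4, `O=c1[nH]c(SCc2cc([N+](=O)[O-])cc([N+](=O)[O-])c2)nc2cc(Cl)ccc12`, is not yet measured in this assay. It differs from compound 1 by chloro in place of hydrogen on an aromatic carbon. The difference between the core of compound 1 and the core of compound 2 is not broken down here. The change from compound 1 to compound 4 is the same kind of change as that from compound 2 to compound 3, but the place is not the same: in compound 3 the chloro sits on a six-membered aromatic ring of carbon only, ortho to a large group, whereas in compound 4 it sits on a six-membered aromatic ring of carbon only that is part of a fused or bridged system of two rings, meta to a fused ring and para to a fused ring.

For compound 4 the expected step in this assay is a step that the limit leaves unreadable from compound 1 to compound 4, resting on the unreadable measured step that the two limits leave unreadable from compound 2 to compound 3, which gives no reason to expect movement off the limit. This expectation also rests on compound 1, whose value > 64000 nM is a limit. Compound 4 is expected to give 70000 nM, most probably reported once more as a limit rather than a number.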

Compound 4, half-maximal cytotoxic concentration: > 64000 nM
Compound 4: a limit, no number; the forecaster's own chance of this, stated with the estimate: 85%; the middle value does not contradict the limit.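

In this assay compound 4 gives > 64000 nM, which is a limit of the assay and not a number. Compound 1 also stands at a limit, and no step can be read from compound 1 to compound 4. The compounds shown leave open whether chloro in place of hydrogen on an aromatic carbon changes the half-maximal cytotoxic concentration at all, at either place.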